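Permeability notes: carbamoyl variant of the propanoyl piperidine

This account rests on a few compounds, and the source may have more. Where it says the series, first, only, none or still open, it means among the compounds named here.

Measured in an ADME assay on Caco-2 cells (Homo sapiens) for permeability, in the apical to basolateral direction; a lower number here means that the compound crosses the layer more slowly, a higher number that the compound crosses the layer faster:
compound 1 `CCC(=O)N1CCC(CN(C2Cc3cc(C#N)ccc3N(Cc3cncn3C)C2)S(=O)(=O)c2ccccn2)CC1`: 0.5 10^-6 cm/s
compound 2 `Cn1cncc1CN1CC(N(CC2CCN(C(=O)CC(F)(F)F)CC2)S(=O)(=O)c2ccccn2)Cc2cc(C#N)ccc21`: 0.5 10^-6 cm/s

Compound 1 stands level with compound 2 at the digits shown; the only measured step, no change at the digits printed from compound 1 to compound 2 (within the scatter), concerns a trifluoromethyl in place of methyl on a saturated chain carbon bound to a carbonyl carbon and leaves the read-out where it was.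

Compound 3 `Cn1cncc1CN1CC(N(CC2CCN(C(=O)NC(C)(C)C)CC2)S(=O)(=O)c2ccccn2)Cc2cc(C#N)ccc21` is not yet measured in this assay. It differs from compound 1 as follows: (tert-butyl)amino in place of ethyl on a carbonyl carbon

Going by the values given here, no measured step covers this exchange at the carbonyl carbon; the step from compound 1 to compound 2 sits at a different position and is of a different kind, so it bears only as a sign that the series has so far not moved. For compound 3 the step of a 1.3-fold lower number from compound 1 to compound 3 (0.10 log units; within the scatter) is therefore expected to stay within the scatter, leaning downward if anywhere. Compound 3 is estimated at 0.4 10^-6 cm/s, with a range of 0.15 10^-6 cm/s to 1.2 10^-6 cm/s.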

Compound 3, apparent permeability: 0.6 10^-6 cm/s
The estimate for compound 3 lay 1.5-fold (0.18 log units) below the measured number; measured number inside the range.
By their numbers in this assay, from the lowest: compounds 1, 2 and 3 (each within the scatter of the next).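

Exchanging the ethyl on the carbonyl carbon for (tert-butyl)amino, which brings in a hydrogen-bond donor and turns propanoyl into (tert-butyl)carbamoyl, gives a 1.2-fold higher number from compound 1 to compound 3 (0.08 log units; within the scatter) in this assay. Set against 2,2,2-trifluoroethyl at the same place, (tert-butyl)amino gives a 1.2-fold higher number from compound 2 to compound 3 (0.08 log units; within the scatter), so ethyl, 2,2,2-trifluoroethyl and (tert-butyl)amino on this carbonyl carbon all read alike in this assay, and the added donor brings no step beyond the scatter. Nothing at hand gives a reason for this flat reading.

Still open, going by these compounds, is whether any group on this carbonyl carbon, such as a carboxylic acid, a dimethylamino group or a longer chain, would carry the read-out beyond the scatter. On these data alone, all three compounds share the core of compound 1, so the effect of changes elsewhere in the core also remains unknown.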